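The source may report more compounds than this note shows. Statements on the series, on what has been measured and on what is new or still open speak of the compounds shown alone.

Measured in a functional assay for inhibition, with Homo sapiens as the target; a higher number here means a weaker inhibitor, a lower number a stronger inhibitor:
Compound 1 `COc1cc(OC)c(C(=O)/C=C/c2cnccn2)c(OC)c1`: 693 nM
Compound 2 `CCOc1ccccc1C(=O)/C=C/c1ccccc1`: 609 nM
Compound 3 `O=C(/C=C/c1ccccc1)c1ccccc1[N+](=O)[O-]`: 1520 nM

Of these three, compound 3 has the highest number, 1520 nM, and is therefore the weakest inhibitor of the set. Compound 4 `O=C(/C=C/c1ccccc1)c1ccccc1C(F)(F)F` has not yet been measured. It differs from compound 3 by one change, trifluoromethyl in place of nitro on an aromatic carbon, ortho to a large group.

Among the compounds with values here, only one measured step bears on this change: a 2.5-fold higher number from compound 2 to compound 3 (0.40 log units; beyond the scatter). This modest step swapped ethoxy for nitro on an aromatic carbon, so it involves the group that leaves here. Within the data shown here, no measured compound other than compound 4 carries trifluoromethyl, however, and the data contain no direct comparison of the two groups. The step therefore gives only a rough idea of how far such a swap can move the number, not a firm direction. Starting from compound 3 at 1520 nM, and with a 2.5-fold higher number from compound 2 to compound 3 (0.40 log units; beyond the scatter) as the only guide, a small shift is expected. The expected step, a 1.3-fold lower number from compound 3 to compound 4 (0.10 log units; within the scatter), leans slightly towards a lower number and is not expected to be clearly resolved from the scatter. For compound 4 the estimate is 1200 nM, with an expected range from 500 nM to 3000 nM.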

Compound 4, half-maximal inhibitory concentration: 748 nM
The estimate for compound 4 lay 1.6-fold (0.21 log units) above the measured number, and the stated range covers the measured number.
By their numbers in this assay, from the lowest: compounds 2, 1 and 4 (each within the scatter of the next); then compound 3.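

In this assay, within the data shown here, trifluoromethyl in place of nitro on an aromatic carbon, ortho to a large group, gives a 2.0-fold lower number from compound 3 to compound 4 (0.31 log units; beyond the scatter) as the first direct comparison of these two groups at this position, a modest step that is beyond the scatter. Trifluoromethyl and ethoxy at this same place cannot be told apart, with a 1.2-fold higher number from compound 2 to compound 4 (0.09 log units; within the scatter) in the same assay, so among the three groups seen here only nitro separates from the others, and three groups support no wider pattern. Nothing available explains why nitro stands apart from ethoxy and trifluoromethyl at this position.

The compounds shown leave open how other groups at this place would read, such as an amine, a carboxylic acid, a nitrile or a longer alkoxy chain, and whether any of them would stay level with ethoxy and trifluoromethyl or move with nitro. They also leave open whether the gap between nitro and trifluoromethyl would persist on a different core, such as the core of compound 1.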